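The source may hold more compounds than are shown below. What is called first, only, known or untested is meant among the compounds shown, and "the series" means these compounds.

Working notes on the series. Compound 1 `CN(C)C(=O)c1nc([C@@H](O)[C@H](O)[C@H](O)CO)c[nH]1` in an ADME assay on the whole organism (strain 129/SvEvBrd x C57BL/6) for metabolic stability, with Mus musculus as the target (a lower number here means that the compound disappears faster, a higher number that the compound lasts longer), gives 4 h. For the measured compounds named here, the only other measured member, compound 2 `OC[C@@H](O)[C@@H](O)[C@H](O)c1c[nH]c(-c2ncn(Cc3ccccc3)n2)n1`, gives 2.4 h in this assay; the two values stand within the usual scatter of each other, so compound 1 has the higher of the two numbers without being separated from compound 2 in any meaningful way.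

Compound 3 `OC[C@@H](O)[C@@H](O)[C@H](O)c1c[nH]c(-c2ncon2)n1` has not yet been measured. Relative to compound 1 the change is 1,2,4-oxadiazol-3-yl in place of dimethylcarbamoyl on an aromatic carbon. Going by the values given here, no measured pair covers this kind of change, so nothing in the data fixes its size. Given that compound 1 and compound 2 sit close together despite quite different groups at that position, the step from compound 1 to compound 3 is expected to be small, a 1.3-fold lower number from compound 1 to compound 3 (0.12 log units; within the scatter), with no clear direction beyond the scatter. Compound 3 is therefore estimated at 3 h in this assay, within a range of 1.5 h to 6 h.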

Compound 3, half-life: 0.7 h
Compound 3: middle estimate off by 4.3-fold (0.63 log units), on the high side; measured number outside the range, below it.
By their numbers in this assay, from the lowest: compound 3; then compounds 2 and 1 (each within the scatter of the next).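

In this assay, 1,2,4-oxadiazol-3-yl in place of dimethylcarbamoyl on an aromatic carbon gives a 5.7-fold lower number from compound 1 to compound 3 (0.76 log units; beyond the scatter), so the group at this position can shift the half-life beyond the scatter. The two groups have the same heavy-atom count and neither has a hydrogen-bond donor, so the step comes with no change in either count; they differ in the aromatic ring and in the number of hydrogen-bond acceptors. Nothing available gives a reason for the step.

This single pair cannot separate the contribution of the entering ring from that of the leaving dimethylcarbamoyl group. On these data alone, it remains open whether a primary carboxamide or a carboxylic acid at this position would give a half-life closer to that of compound 1 or to that of compound 3.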